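The source may hold more compounds than are shown below. What is called first, only, known or untested is meant among the compounds shown, and "the series" means these compounds.

Measured so far in an assay on BTI-TN-5B1-4 cells for inhibition of Amine oxidase [flavin-containing] A (Homo sapiens), read by fluorescence and Amplex Red, using microsomes, with a stated time of 30 min; on this read-out lower numbers stand for stronger inhibition and higher numbers for weaker inhibition:
compound 1, `C#CCOc1ccc(-c2cc(-c3ccc(OCC#C)cc3)nc(C)n2)cc1`: 34200 nM
compound 2, `C#CCOc1ccc(-c2cc(-c3ccc(OCC#C)c(OC)c3)nc(N)n2)cc1`: "not active" (no number reported)

Compound 2 has no single number to stand on: in this assay compound 2 is recorded as "not active" (no number reported), so no inhibitory concentration can be quoted for it and its distance from compound 1 cannot be put in figures. Compound 1, with a methyl on the shared core, gives a weak but measurable value.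

Compound 3, `C#CCOc1ccc(-c2cc(-c3ccc(OCC#C)c(OC)c3)nc(C)n2)cc1`, is not yet measured. Against compound 2 the change is methyl in place of amino on an aromatic carbon, sitting on an aromatic carbon of a six-membered aromatic ring with 2 nitrogen, between two ring nitrogen atoms, meta to two large groups; the entering group is the one compound 1 carries at that position.

Going by the values given here, no step between measured compounds exists, so the size of the step in this assay is not fixed by data; the direction is taken as toward measurable inhibition, since compound 2 gives no number while compound 1 gives 34200 nM. Compound 1 and compound 3 differ elsewhere as well, and that difference is unmeasured.

Compound 3 is expected to give 40000 nM in this assay, within a range from 10000 nM to 200000 nM, with a real chance that only a statement of no activity is returned.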

Compound 3, half-maximal inhibitory concentration: 25000 nM
Compound 3: the middle estimate sits 1.6-fold (0.20 log units) above what was measured, and the stated range covers the measured number.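

Methyl in place of amino on an aromatic carbon, between two ring nitrogen atoms, is the one change separating compound 2 from compound 3, and it makes the difference between a record without a number and a measurable value: in this assay compound 2 gives "not active" (no number reported), whereas compound 3 gives 25000 nM, so the size of this step cannot be read. Methoxy in place of hydrogen on an aromatic carbon gives a 1.4-fold lower number from compound 1 to compound 3 (0.14 log units; within the scatter), so with methyl on the shared core, the methoxy does not stand in the way of a measurable value, and within this pair the record without a number goes with amino rather than with methoxy. Nothing on hand accounts for the contrast between amino and methyl at this position.

The compounds shown leave open how other groups at this position would read in this assay, for instance an ethyl, a hydroxyl or a dimethylamino group, and whether any of them would lie apart from methyl beyond the scatter. They also leave open whether amino gives the same record on the core of compound 1, which lacks the methoxy.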